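From (piperidin-1-yl)methyl to (pyrrolidin-1-yl)carbonyl on the urea chain

This account rests on a few compounds, and the source may have more. Where it says the series, first, only, none or still open, it means among the compounds named here.

In a functional assay on U-87MG ATCC cells for cytotoxicity against U-87 MG (Homo sapiens), read by MTT assay, with a stated time of 72 h (on this read-out higher numbers stand for weaker inhibition and lower numbers for stronger inhibition), compound 1 `COc1ncc(-c2ccc3nc(NC(=O)NC4CC4)nn3c2)cc1NS(=O)(=O)c1ccc(F)cc1` gives 540 nM and compound 2 `COc1ncc(-c2ccc3nc(NC(=O)NCCN4CCCCC4)nn3c2)cc1NS(=O)(=O)c1ccc(F)cc1` gives 1080 nM as its half-maximal inhibitory concentration. These two numbers lie within the usual scatter of each other, so compound 2 cannot be ranked apart from compound 1.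

Compound 3 `COc1ncc(-c2ccc3nc(NC(=O)NCC(=O)N4CCCC4)nn3c2)cc1NS(=O)(=O)c1ccc(F)cc1` has not yet been measured. Its structure differs from that of compound 2 by (pyrrolidin-1-yl)carbonyl in place of (piperidin-1-yl)methyl on a saturated chain carbon bound to an amide-type nitrogen and so carries (pyrrolidin-1-yl)carbonyl in place of (piperidin-1-yl)methyl on a saturated chain carbon bound to an amide-type nitrogen.

Within the data shown here, only one measured step bears on this, a 2.0-fold higher number from compound 1 to compound 2 (0.30 log units; within the scatter) for 2-(piperidin-1-yl)ethyl in place of cyclopropyl on that same nitrogen. Among the measured compounds shown here, no measured step tests the new carbonyl group, so no shift beyond the scatter is expected in this assay here. The expected change is a 1.4-fold lower number from compound 2 to compound 3 (0.13 log units; within the scatter) and stays within the scatter. For compound 3 the estimated value is 800 nM with a range from 300 nM to 2200 nM as expected bounds.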

Compound 3, half-maximal inhibitory concentration: 1000 nM
Compound 3: the middle estimate sits 1.3-fold (0.10 log units) below what was measured; low and high end bracket the measured number.
By their numbers in this assay, from the lowest: compounds 1, 3 and 2 (each within the scatter of the next).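

In this assay, the change on the chain at the amide-type nitrogen gives a 1.1-fold lower number from compound 2 to compound 3 (0.03 log units; within the scatter), so introducing a carbonyl and changing from a six-membered to a five-membered ring together produce no readable change. The comparison with the small ring gives a 1.9-fold higher number from compound 1 to compound 3 (0.27 log units; within the scatter) for ((pyrrolidin-1-yl)carbonyl)methyl in place of cyclopropyl, so compounds 1, 2 and 3 cannot be told apart despite their three different groups on this nitrogen. No supporting measurement accompanies these numbers to explain this result.

Compound 3 alters the ring and the carbonyl at once. A 2-(pyrrolidin-1-yl)ethyl group would be needed to separate the two changes. Going by these compounds, whether a carboxylic acid or a longer chain on this nitrogen would shift the number beyond the scatter remains open.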